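From propyl to 1-phenylethyl on the amine nitrogen

The compounds below may be only part of what the source reports. "The series", "measured", "known", "first", "only" and "open" are said of these compounds alone.

Compound 1 `CCCNC(=O)C1CCN(C(=O)c2cc3sccc3n2Cc2ccc(OC)cc2)CC1`: 18800 nM
Compound 2 `CCCNC(=O)C1CCN(C(=O)c2c(CO)c3sccc3n2Cc2ccc(OC)cc2)CC1`: > 100000 nM, a limit
Compound 3 `CCCNCc1c(C(=O)N2CCC(C(=O)NCCC)CC2)n(Cc2ccc(OC)cc2)c2ccsc12`: > 100000 nM, a limit

In an ADME assay on HEK-293T cells (Homo sapiens) for cytotoxicity, read by luminescence, with a stated time of 24 h (a lower number here means that less compound is tolerated, a higher number that more compound is tolerated), compound 3 gives > 100000 nM, which is a limit and not a number. Compound 4 `CCCNC(=O)C1CCN(C(=O)c2c(CNC(C)c3ccccc3)c3sccc3n2Cc2ccc(OC)cc2)CC1` carries 1-phenylethyl in place of propyl on an amine nitrogen. Among the measured compounds shown here, no measured step changes this group directly. The nearest evidence is an at least 5.3-fold higher number from compound 1 to compound 2 (0.72 log units; beyond the scatter) and an at least 5.3-fold higher number from compound 1 to compound 3 (0.72 log units; beyond the scatter), while a step that the two limits leave unreadable from compound 2 to compound 3 cannot be sized. Both substituents reached the limit, so only a moderate downward shift is expected, and perhaps none. The expected change is an at least 1.6-fold lower number from compound 3 to compound 4 (0.22 log units; that floor lies within the scatter). Compound 4 is estimated at 60000 nM, with an expected range from 18000 nM to 100000 nM.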

Compound 4, half-maximal cytotoxic concentration: 57500 nM
The estimate for compound 4 lay 1.0-fold (0.02 log units) above the measured number, and the stated range covers the measured number.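

In this assay, compound 4 gives a number where compound 2 and compound 3 give only limits, with an at least 1.7-fold lower number from compound 3 to compound 4 (0.24 log units; that floor lies within the scatter) and an at least 1.7-fold lower number from compound 2 to compound 4 (0.24 log units; that floor lies within the scatter). The gain over the hydrogen of the shared core persists with the larger group, at a 3.1-fold higher number from compound 1 to compound 4 (0.49 log units; beyond the scatter). The two steps with floors stay open-ended, and their true sizes cannot be read: the limit of > 100000 nM in this assay, at which 2 of the 4 values shown sit.

On these data alone, whether the change on the amine nitrogen has any effect beyond the scatter therefore remains open. So does whether a benzyl group there would behave like 1-phenylethyl.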